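Swapping a Naphthyl Amide for a Methylphenyl Amide

This account rests on a few compounds, and the source may have more. Where it says the series, first, only, none or still open, it means among the compounds named here.

Compounds measured so far:
compound 1, `Cc1nnc(Sc2cc(NC(=O)c3ccc(Cl)cc3)c3ccccc3c2O)s1` — 8.48%
compound 2, `O=C(Nc1cc(Sc2ncn[nH]2)c(O)c2ccccc12)c1ccc2ccccc2c1` — 41.6%
compound 3, `O=C(Nc1cc(Sc2ncnc3nc[nH]c23)c(O)c2ccccc12)c1ccc(Cl)cc1` — 21.7%

All three share a core carrying a hydroxyl, an amide and a thioether, and were tested in an assay on isolated protein for inhibition of RAC-alpha serine/threonine-protein kinase (Homo sapiens), read by fluorescence, with a stated time of 30 min, tested at 10 uM; on this read-out higher numbers stand for more inhibition at the one concentration tested (going by the name of the read-out) and lower numbers for less inhibition. Compound 2 stands highest of the three: compound 3 lies nearest, and compound 1 furthest, both gaps beyond the scatter. Compound 4, `Cc1cccc(C(=O)Nc2cc(Sc3ncn[nH]3)c(O)c3ccccc23)c1`, is not yet measured. It differs from compound 2 only at the amide: 3-methylphenyl in place of naphthalen-2-yl on a carbonyl carbon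

Among the compounds with values here, no measured step changes the amide aryl group, so nothing bears directly on this change. Within the data shown here, the one measured step, a number 13.2 percentage points higher from compound 1 to compound 3 (beyond the scatter), alters the group on the sulfur instead and shows that this series can shift by a modest amount on a single ring exchange. Compound 1 and compound 3, which carry the same aryl amide as each other, both sit well under compound 2, which hints that the amide aryl matters but cannot say how.

Compound 4 is therefore expected to lose some inhibition, with the step of a number 16.6 percentage points lower from compound 2 to compound 4 (beyond the scatter) as a working guess, and an estimate of 25% within a range of 8% to 45%.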

Compound 4, a percentage reported as inhibition, at one concentration (the size of the read-out at that concentration, not a potency): 20.2%
Compound 4: middle estimate off by 4.8 percentage points, on the high side; low and high end bracket the measured number.
By their numbers in this assay, from the lowest: compound 1; then compounds 4 and 3 (each within the scatter of the next); then compound 2.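

In this assay, placing 3-methylphenyl in place of naphthalen-2-yl on a carbonyl carbon, with the rest of the structure unchanged, gives a number 21.4 percentage points lower from compound 2 to compound 4 (beyond the scatter). Within the data shown here, this is the first direct reading at this position, and it shows that the group on the amide carbonyl can move inhibition by more than the scatter even when the group on the sulfur stays the same. The step goes with a change from two six-membered aromatic rings of carbon to one, while the counts of hydrogen-bond donors and acceptors and the net charge stay the same, and no measurement here explains why inhibition falls.

This single pair changes the ring count and adds a methyl at once, so it cannot separate the loss of the second ring from the effect of the methyl. Also open, from the compounds shown here alone, is how a plain phenyl, a pyridine ring or a phenyl carrying an amine would read on the same carbonyl carbon, and whether a similar step would appear with a different group on the sulfur.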